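The source may hold more compounds than are shown below. What is called first, only, known or untested is meant among the compounds shown, and "the series" means these compounds.

Measured compounds:
- Compound 1, `Cc1ccc(S(=O)(=O)N2CCC(Cl)CC2)cc1`: in a functional assay on A2780 cells (Homo sapiens) for antiproliferative activity, read by sulforhodamine B assay, with a stated time of 48 h (a higher number here means a weaker inhibitor of growth, a lower number a stronger inhibitor of growth), compound 1 returns a limit, > 100000 nM.
- Compound 2, `Cc1ccc(S(=O)(=O)N2CC[C@@H](Cl)C[C@@H]2CC(C)C)cc1`: in this assay compound 2 gives 36000 nM.

Among the measured compounds shown here, compound 2 is the only compound of the pair with a numerical value in this assay; the other entry is a limit (the limit of > 100000 nM in this assay, at which 1 of the 2 values shown sits). For the measured compounds named here, the one measured step, an at least 2.7-fold lower number from compound 1 to compound 2 (0.44 log units; beyond the scatter), shows that adding the branched side chain on the saturated ring carbon moves the read-out from a limit to a measurable number.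

Compound 3, `CCCCCCC[C@H]1C[C@H](Cl)CCN1S(=O)(=O)c1ccc(C)cc1`, differs from compound 2 by hexyl in place of isopropyl on a saturated chain carbon bound to a saturated ring carbon. Going by the values given here, no measured step tests lengthening of this chain, so the only guide is that a side chain on this ring carbon helped in an at least 2.7-fold lower number from compound 1 to compound 2 (0.44 log units; beyond the scatter). A step of the size a 1.8-fold lower number from compound 2 to compound 3 (0.26 log units; within the scatter) is expected, a small shift toward stronger growth inhibition that may well stay within the scatter. Compound 3 is estimated at 20000 nM in this assay, between 6000 nM and 60000 nM.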

Compound 3, concentration for 50% growth inhibition: > 100000 nM
Compound 3 ended at the assay's limit (the forecaster's own chance of this, stated with the estimate: 10%); middle value at least 5.0-fold (0.69 log units) from the limit.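

Lengthening the side chain at this position does not carry the earlier gain forward: in this assay, hexyl in place of isopropyl on a saturated chain carbon bound to a saturated ring carbon gives an at least 2.7-fold higher number from compound 2 to compound 3 (0.44 log units; beyond the scatter). The step from compound 1 to compound 3 cannot be read, since both values are limits, so no difference between heptyl and hydrogen on this ring carbon can be stated. Among the compounds shown, a measurable number belongs to the isobutyl side chain of compound 2 alone, and the other two entries are limits: the limit of > 100000 nM in this assay, at which 2 of the 3 values shown sit.

Going by these compounds, it remains open where between isobutyl and heptyl the measurable number is lost, and whether a shorter chain such as ethyl gives one at all. Also open, on these data alone, is whether a side chain carrying an amine or a carboxylic acid, or a cyclohexyl group, reads like isobutyl or like heptyl on this carbon.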